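Ethyl on the benzo ring of the pentyl aminobenzimidazole series

A few compounds are considered here, and "the series" means these few. Any claim that something is new, unique, unknown or untested is made for them only; others in the source may bear on it.

Going by the values given here, compound 1 `CCCCCn1c(N)nc2ccccc21` gives 3230 nM in an assay on HEK293 cells for agonist activity at Toll-like receptor 8 (Homo sapiens), read by reporter gene assay (on this read-out lower numbers stand for an effect already at smaller amounts and higher numbers for an effect only at larger amounts of compound), and holds the lowest of the three numbers so far. Compound 2 `CCCCCCn1c(N)nc2ccccc21` gives 3960 nM in this assay; the step of a 1.2-fold higher number from compound 1 to compound 2 (0.09 log units; within the scatter) is within the scatter. Compound 3 `CCCCCn1c(N)nc2cccc(C)c21` gives 6610 nM in this assay; the step of a 2.0-fold higher number from compound 1 to compound 3 (0.31 log units; beyond the scatter) is a modest shift to a higher number.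

Compound 4 `CCCCCn1c(N)nc2c(CC)cccc21` differs from compound 1 by ethyl in place of hydrogen on an aromatic carbon, the ethyl sitting on an aromatic carbon of a six-membered aromatic ring of carbon only, part of a fused system of two rings, ortho to a fused ring and meta to a fused ring. Among the compounds with values here, the only measured step that bears on it is the aromatic methyl of a 2.0-fold higher number from compound 1 to compound 3 (0.31 log units; beyond the scatter); the chain extension of a 1.2-fold higher number from compound 1 to compound 2 (0.09 log units; within the scatter) is of another kind and stayed within the scatter. A modest step to a higher number is therefore expected, a 2.0-fold higher number from compound 1 to compound 4 (0.30 log units; within the scatter). Compound 4 is estimated at 6500 nM in this assay, within 3000 nM to 14000 nM.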

Compound 4, half-maximal effective concentration: 1650 nM
Beside the measured number, compound 4's estimate is 3.9-fold (0.60 log units) above it, and the stated range ends above it.
By their numbers in this assay, from the lowest: compounds 4, 1, 2 and 3 (each within the scatter of the next, the first and the last beyond it).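

In this assay, ethyl in place of hydrogen on this aromatic carbon, ortho to a fused ring and meta to a fused ring, gives a 2.0-fold lower number from compound 1 to compound 4 (0.29 log units; within the scatter), so this larger group leaves the number of the unsubstituted core within the scatter. The earlier aromatic change gave a 2.0-fold higher number from compound 1 to compound 3 (0.31 log units; beyond the scatter), so a substituent on an aromatic carbon of this ring does not necessarily carry a step beyond the scatter, although compounds 3 and 4 differ in more than one place and group cannot be separated from position. No available evidence accounts for the result.

Open, as far as these compounds go, is how methyl, propyl or an amine would read on the aromatic carbon bearing ethyl in compound 4. Also open, from the compounds shown here alone, is whether ethyl there gives a similar step with the hexyl chain of compound 2.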